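The source may report more compounds than this note shows. Statements on the series, on what has been measured and on what is new or still open speak of the compounds shown alone.

Measured compounds:
compound 1, `C=C1CC[C@@H]2[C@](C)(COC(C)=O)[C@H](OC(C)=O)CC[C@@]2(C)[C@@H]1C/C=C1/C(=O)OC[C@H]1OC(C)=O`: 10.8 uM
compound 2, `C=C1CC[C@@H]2[C@](C)(CO)[C@H](OC(C)=O)CC[C@@]2(C)[C@@H]1C/C=C1/C(=O)OC[C@H]1O`: 27.2 uM

Compound 1 and compound 2 were both tested in a functional assay on Col2 cells (Homo sapiens) for cytotoxicity, read by sulforhodamine B assay; on this read-out lower numbers stand for an effect already at smaller amounts and higher numbers for an effect only at larger amounts of compound. In this assay compound 1 gives 10.8 uM, while compound 2 gives 27.2 uM. Compound 2 therefore stands at the higher of the two numbers, and the gap to compound 1 lies beyond the usual scatter of this kind of measurement.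

Compound 3, `C=C1CC[C@@H]2[C@](C)(CO)[C@H](OC(C)=O)CC[C@@]2(C)[C@@H]1C/C=C1/C(=O)OC[C@H]1OC(C)=O`, has not yet been measured in this assay. It differs from compound 2 in one place: acetyl in place of hydrogen on an oxygen on a saturated carbon. With this change compound 3 sits between compound 2 and compound 1, carrying one of the acetyl groups that compound 2 lacks. On that basis a move toward the lower number of compound 1 is expected, of the size a 1.7-fold lower number from compound 2 to compound 3 (0.23 log units; within the scatter), a step that may be close to the scatter. For compound 3 a value of about 16 uM is estimated, with a range from 8 uM to 32 uM.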

Compound 3, concentration for half-maximal effect: 10.2 uM
Estimate against measurement, compound 3: 1.6-fold (0.20 log units) above; measured number inside the range.
By their numbers in this assay, from the lowest: compounds 3 and 1 (each within the scatter of the next); then compound 2.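

In this assay the hydroxy to acetoxy change on an oxygen on a saturated carbon whose other neighbour is a saturated ring carbon gives a 2.7-fold lower number from compound 2 to compound 3 (0.43 log units; beyond the scatter), a modest step beyond the scatter. Compound 1 and compound 2 differ in two places, so their gap alone could not be assigned to either acetyl group. Adding the step of a 1.1-fold lower number from compound 1 to compound 3 (0.02 log units; within the scatter), which is within the scatter, shows that the acetyl group at the other oxygen, present in compound 1 and absent from compound 3, makes no visible difference here, so this one position accounts for the gap.

As far as these compounds go, whether a longer ester such as propanoyl, a methyl ether or an amine at this position would read like the acetoxy or the hydroxy compound remains open. Nothing given here bears on why the acetyl group has this effect.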